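Working notes on compound 4 in the cytotoxicity series

This account rests on a few compounds, and the source may have more. Where it says the series, first, only, none or still open, it means among the compounds named here.

Measured so far in an ADME assay on L02 cells (Homo sapiens) for cytotoxicity, read by MTT assay, with a stated time of 48 h; on this read-out higher numbers stand for weaker inhibition and lower numbers for stronger inhibition:
- compound 1 `Cc1cccc(Cn2cc(COc3ccc4c(=O)ccoc4c3)nn2)c1`: > 300000 nM, a limit of the assay
- compound 2 `O=c1ccoc2cc(OCc3cn(Cc4ccc(Cl)cc4)nn3)ccc12`: > 300000 nM, a limit of the assay
- compound 3 `Cc1ccccc1Cn1cc(COc2ccc3c(=O)ccoc3c2)nn1`: > 300000 nM, a limit of the assay

Compound 2 stands at the limit, and the other two values shown are limits as well; none of the three is a number, as the limit of > 300000 nM in this assay, at which 3 of the 3 values shown sit, records. The change to compound 4 `O=c1ccoc2cc(OCc3cn(Cc4cccc(F)c4)nn3)ccc12` is 3-fluorophenyl in place of 4-chlorophenyl on a saturated chain carbon bound to an aromatic nitrogen. For the measured compounds named here, three measured steps touch the same position: a step that the two limits leave unreadable from compound 1 to compound 2, a step that the two limits leave unreadable from compound 1 to compound 3 and a step that the two limits leave unreadable from compound 2 to compound 3. Each of them is unreadable, since both ends sit at the limit, so their size cannot be taken from the data. Going by the values given here, no measured step therefore gives a direction for the present change, and there is nothing that sets compound 4 apart from the three measured compounds in this respect. The expectation for the step from compound 2 to compound 4 in this assay is accordingly one of no readable change, written as a step that the limit leaves unreadable from compound 2 to compound 4. Compound 4 is estimated at 450000 nM in this assay, with a range from 150000 nM to 1500000 nM, and most likely the assay will again report only its limit.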

Compound 4, half-maximal inhibitory concentration: > 300000 nM
Compound 4 ended at the assay's limit (the forecaster's own chance of this, stated with the estimate: 85%); the middle value does not contradict the limit.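

For the compounds shown here, no step from compound 1, compound 2 or compound 3 to compound 4 can be read in this assay, since all four compounds end at the same limit of the assay: the limit of > 300000 nM in this assay, at which 4 of the 4 values shown sit. The compounds shown leave open how far these four compounds differ from one another, and whether any group at this place on the shared core gives a measurable value.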